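A few compounds are considered here, and "the series" means these few. Any claim that something is new, unique, unknown or untested is made for them only; others in the source may bear on it.

Compound 1 `COc1ccc(-c2nc(/N=C(\N)[N+]3(C)CCCCC3)sc2-c2ccc(OC)cc2)cc1` stands only at a limit: in a functional assay with Oryctolagus cuniculus as the target (on this read-out lower numbers stand for stronger inhibition and higher numbers for weaker inhibition), compound 1 gives > 1000 nM, which is a limit of the assay rather than a number. Compound 2 `COc1ccc(-c2nc(CN)sc2-c2ccc(OC)cc2)cc1` also sits at a limit, giving > 100 nM in this assay. The step that the two limits leave unreadable from compound 1 to compound 2 cannot be sized because the limit of > 100 nM in this assay, at which 1 of the 2 values shown sits, and the limit of > 1000 nM in this assay, at which 1 of the 2 values shown sits, are both limits. Compound 3 `COc1ccc(-c2nc(CNC(=O)NC(C)C)sc2-c2ccc(OC)cc2)cc1` carries the change (a group of 8 heavy atoms (5 carbon, 2 nitrogen, 1 oxygen; no ring) in place of a group of 10 heavy atoms (7 carbon, 3 nitrogen; one six-membered non-aromatic ring with 1 hetero atom), on an aromatic carbon). For the measured compounds named here, no measured step bears on this change, so the data give no direction for it. Compound 3 is expected to give 3000 nM, between 500 nM and 20000 nM, an estimated step that the limit leaves unreadable from compound 1 to compound 3.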

Compound 3, half-maximal inhibitory concentration: 42 nM
Compound 3: the middle estimate sits 71-fold (1.85 log units) above what was measured, and the stated range ends above it.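

For the compounds shown here, compound 3 is the first compound here to give a real number rather than a limit, so this position on the five-membered ring can now carry a group with measurable strength in this assay. Replacing the charged piperidine-bearing group with ((isopropylcarbamoyl)amino)methyl gives an at least 23-fold lower number from compound 1 to compound 3 (1.37 log units; beyond the scatter). Putting isopropylcarbamoyl in place of hydrogen on the amine nitrogen gives an at least 2.3-fold lower number from compound 2 to compound 3 (0.37 log units; beyond the scatter). The compounds shown leave open which part of the new group matters, and whether ethylcarbamoyl, butylcarbamoyl or acetyl on the same nitrogen would give a similar value.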